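The compounds below may be only part of what the source reports. "The series", "measured", "known", "first", "only" and "open" are said of these compounds alone.

Working notes on the series.

The shared core of compound 1 `CNc1cc(Oc2ccc(NC(=O)Nc3cccc(C)c3)cc2)ncn1` carries a methyl on the outer aryl ring; in an assay on isolated protein for inhibition of serine/threonine-protein kinase TNNI3K (Homo sapiens) (on this read-out higher numbers stand for weaker inhibition and lower numbers for stronger inhibition), compound 1 gives 1260 nM. Compound 2 `CNc1cc(Oc2ccc(NC(=O)Nc3cccc(C(F)(F)F)c3)cc2)ncn1` replaces that methyl by trifluoromethyl, and in this assay compound 2 gives 40 nM. The step of a 32-fold lower number from compound 1 to compound 2 (1.50 log units; beyond the scatter) is the largest change seen so far. Compound 3 `CNc1cc(Oc2ccc(NC(=O)Nc3cccc(C(F)(F)F)c3)cc2C)ncn1` adds a methyl to the central ring; in this assay compound 3 reaches <= 10 nM, which is a limit of the assay and not a number. The step of an at least 4.0-fold lower number from compound 2 to compound 3 (0.60 log units; beyond the scatter) reads against that limit (the limit of <= 10 nM in this assay, at which 1 of the 3 values shown sits). Among the numbers actually reported, compound 2 stands lowest, with compound 1 the nearest neighbour.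

Compound 4 `CC(C)(O)CNc1cc(Oc2ccc(NC(=O)Nc3cccc(C(F)(F)F)c3)cc2)ncn1` differs from compound 2 only by 1-hydroxy-1-methylethyl in place of hydrogen on a saturated chain carbon bound to a nitrogen on an aromatic ring. Neither measured step touches that place: both concern substituents on aromatic carbons. Going by the values given here, no step therefore bears directly on this change, and the expected step of no change at the digits printed from compound 2 to compound 4 (within the scatter) from compound 2 to compound 4 is none beyond the scatter. Compound 4 is estimated at 40 nM, with a range from 12 nM to 130 nM in this assay.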

Compound 4, half-maximal inhibitory concentration: 40 nM
The estimate for compound 4 equals the measured number at the digits printed, and the stated range covers the measured number.
By their numbers in this assay, from the lowest: compounds 2 and 4 (each within the scatter of the next); then compound 1. At a limit, below all of these: compound 3.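

The change from methylamino to (2-hydroxy-2-methylpropyl)amino gives no change at the digits printed from compound 2 to compound 4 (within the scatter) in this assay. This is the first change shown at the saturated chain carbon bound to a nitrogen on an aromatic ring, and here four heavy atoms, including one hydrogen-bond donor and one acceptor, enter without a step beyond the scatter, unlike the two earlier changes on aromatic carbons. Nothing at hand gives a cause for this result.

The compounds shown leave open whether this place would accept a basic amine, a carboxylic acid or a longer chain equally, since one branched hydroxyalkyl group cannot settle that. As far as these compounds go, it also remains open whether 2-hydroxy-2-methylpropyl keeps its standing when combined with the central-ring methyl of compound 3.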